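A few compounds are considered here, and "the series" means these few. Any claim that something is new, unique, unknown or untested is made for them only; others in the source may bear on it.

Compound 1 `CCCNc1nnc(SCC(=O)N(Cc2cccc([N+](=O)[O-])c2)c2ccc(F)cc2)s1` — 20.5%
Compound 2 `C=CCNc1nnc(SCC(=O)N(Cc2cccc([N+](=O)[O-])c2)c2ccc(F)cc2)s1` — 20.5%

Both were measured in an assay on isolated protein for inhibition of Amine oxidase [flavin-containing] A (Homo sapiens), read by fluorescence and Amplex Red, with a stated time of 30 min, tested at 1 nM; on this read-out lower numbers stand for a weaker effect and higher numbers for a stronger effect at the one concentration tested. Compound 1 gives 20.5% and stands level with compound 2, which gives 20.5%; the step of no change at the digits printed from compound 1 to compound 2 (within the scatter) lies within the scatter. Compound 3 `CC(C)Nc1nnc(SCC(=O)N(Cc2cccc([N+](=O)[O-])c2)c2ccc(F)cc2)s1` is not yet measured. It differs from compound 1 by isopropyl in place of propyl on a nitrogen on an aromatic ring. Among the compounds with values here, no measured step swaps propyl for isopropyl; the only step on this chain, no change at the digits printed from compound 1 to compound 2 (within the scatter), shows no change. Compound 3 is therefore expected to show no step beyond the scatter, a number 0.5 percentage points lower from compound 1 to compound 3 (within the scatter). Compound 3 is estimated at 20%, between 8% and 32%.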

Compound 3, a percentage reported as inhibition, at one concentration (the size of the read-out at that concentration, not a potency): 13.6%
The estimate for compound 3 lay 6.4 percentage points above the measured number; low and high end bracket the measured number.
By their numbers in this assay, from the lowest: compounds 3, 1 and 2 (each within the scatter of the next).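

In this assay, isopropyl in place of propyl on the nitrogen gives a number 6.9 percentage points lower from compound 1 to compound 3 (within the scatter), and isopropyl in place of allyl gives a number 6.9 percentage points lower from compound 2 to compound 3 (within the scatter). The earlier pair covered only unbranched chains; this result extends the comparison to a branched chain, still without a step beyond the scatter. No evidence bearing on this result is available. The compounds shown leave open whether a longer chain, a cyclohexyl group or a benzyl group on this nitrogen would produce a step beyond the scatter.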